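The source may hold more compounds than are shown below. What is called first, only, known or untested is meant among the compounds shown, and "the series" means these compounds.

In an ADME assay on Huh-7 cells (Homo sapiens) for cytotoxicity, read by MTT assay, with a stated time of 48 h (a higher number here means that more compound is tolerated, a lower number that less compound is tolerated), the measured compounds stand as follows:
- compound 1 `CN(C)CCCCN(C(=O)O)c1ccccc1Cn1nc(-c2ccc(F)cc2)c2ccccc2c1=O` gives 48500 nM
- compound 2 `CN(C)CCCCOC(=O)Nc1ccc(Cn2nc(-c3cccnc3)c3ccccc3c2=O)cc1` gives 68000 nM
- compound 3 `CN(C)CCCCOC(=O)Nc1ccc(Cn2nc(-c3cnn(C)c3)c3ccccc3c2=O)cc1` gives 55900 nM

Compound 3 stands second highest of the three numbers; its nearest neighbour is compound 1 and its furthest is compound 2, and both gaps lie within the scatter, so none of the three compounds is set apart from the others in this assay. Within the data shown here, the one step between measured compounds that differ in a single place, a 1.2-fold lower number from compound 2 to compound 3 (0.09 log units; within the scatter), is within the scatter as well.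

Compound 4 `CN(C)CCCCOC(=O)Nc1ccc(Cn2nc(-c3ccc(C(F)(F)F)cc3)c3ccccc3c2=O)cc1` has not been measured. It differs from compound 3 in one place: 4-(trifluoromethyl)phenyl in place of 1-methyl-1H-pyrazol-4-yl on an aromatic carbon. Among the measured compounds shown here, the only measured step that bears on this change is a 1.2-fold lower number from compound 2 to compound 3 (0.09 log units; within the scatter), which exchanged one aromatic group for another on the shared core and barely moved the number. For the measured compounds named here, no measured step exchanges a five-membered heteroaromatic ring for a trifluoromethyl-bearing phenyl ring, so the size of that particular exchange is not known from these data. Compound 1, with a different aryl group and a differently arranged core, gives a value within the scatter of that of compound 3. The expectation in this assay is therefore no step beyond the scatter, a 1.2-fold lower number from compound 3 to compound 4 (0.09 log units; within the scatter). The estimate for compound 4 is 45000 nM, with a range from 20000 nM to 85000 nM.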

Compound 4, half-maximal cytotoxic concentration: 3360 nM
Estimate against measurement, compound 4: 13-fold (1.13 log units) above; the measured number lies below the stated range.
By their numbers in this assay, from the lowest: compound 4; then compounds 1, 3 and 2 (each within the scatter of the next).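

In this assay, the group on this aromatic carbon next to the ring nitrogen can matter a great deal: 4-(trifluoromethyl)phenyl gives a 17-fold lower number from compound 3 to compound 4 (1.22 log units; beyond the scatter) and a 20-fold lower number from compound 2 to compound 4 (1.31 log units; beyond the scatter), whereas the exchange of pyridin-3-yl for 1-methyl-1H-pyrazol-4-yl gave only a 1.2-fold lower number from compound 2 to compound 3 (0.09 log units; within the scatter). The position therefore does not tolerate every aromatic group equally, and a six-membered aromatic ring alone does not go with the drop, as compound 2 carries pyridin-3-yl and stands with compound 3 at the high end. Nothing at hand accounts for the drop.

The change to compound 4 removes the ring nitrogens and adds the trifluoromethyl group in a single step, so the compounds shown leave open whether the drop follows the carbon-only ring or the trifluoromethyl group, a question that plain phenyl or 4-methylphenyl on the shared core would address. The 4-fluorophenyl group occurs only in compound 1, whose core differs in other places as well, so it offers no one-place comparison on this point.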